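Changing the aryl group on the amide nitrogen

The compounds below may be only part of what the source reports. "The series", "measured", "known", "first", "only" and "open" are said of these compounds alone.

For the measured compounds named here, compound 1 `CN(C)C(=O)c1cc2cnc(Nc3ccc(NC(=O)C4(C(=O)Nc5cccc(F)c5)CC4)cc3)nc2n1C1CCCC1` gives 91.8% in a functional assay on A549 cells (Homo sapiens) for inhibition, read by CCK-8 assay, with a stated time of 72 h, tested at 10 uM (a higher number here means more inhibition of growth at the concentration tested, a lower number less inhibition of growth), and this is the upper one of the two numbers measured so far, with compound 2 sitting within the scatter of it. Going by the values given here, compound 2 `COC(=O)c1cccc(NC(=O)C2(C(=O)Nc3ccc(Nc4ncc5cc(C(=O)N(C)C)n(C6CCCC6)c5n4)cc3)CC2)c1` gives 91% in this assay; the only measured step is a number 0.8 percentage points lower from compound 1 to compound 2 (within the scatter). Compound 3 `CN(C)C(=O)c1cc2cnc(Nc3ccc(NC(=O)C4(C(=O)Nc5ccc(C(F)(F)F)cc5)CC4)cc3)nc2n1C1CCCC1` differs from compound 1 in one place: 4-(trifluoromethyl)phenyl in place of 3-fluorophenyl on an amide-type nitrogen. Among the compounds with values here, the single step that bears on this change, a number 0.8 percentage points lower from compound 1 to compound 2 (within the scatter), also altered the substituent of the aryl group on that amide-type nitrogen and stayed within the scatter, so nothing measured points to this part of the molecule moving the read-out. The step from compound 1 to compound 3 is therefore expected to lie within the scatter, a number 2.8 percentage points lower from compound 1 to compound 3 (within the scatter). Compound 3 is estimated to give 89% in this assay, within a range from 76% to 96%.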

Compound 3, percent growth inhibition at one concentration: 87.9%
Estimate against measurement, compound 3: 1.1 percentage points above, within the range that was stated.
By their numbers in this assay, from the lowest: compounds 3, 2 and 1 (each within the scatter of the next).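

Exchanging 3-fluorophenyl for 4-(trifluoromethyl)phenyl on the amide-type nitrogen gives, in this assay, a number 3.9 percentage points lower from compound 1 to compound 3 (within the scatter). Set against the 3-(methoxycarbonyl)phenyl group, the same aryl group gives a number 3.1 percentage points lower from compound 2 to compound 3 (within the scatter). The three aryl groups on this nitrogen therefore cannot be told apart in this assay, and this now extends to a group named with its substituent at the 4-position rather than the 3-position. No supporting information bears on why the read-out stays level here.

It remains open whether an aryl group carrying an amine or a carboxylic acid would stay within the scatter of these compounds. The same question stands for a longer alkyl chain in place of the aryl group on this nitrogen.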